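A few compounds are considered here, and "the series" means these few. Any claim that something is new, unique, unknown or untested is made for them only; others in the source may bear on it.

Series notes, the step from compound 2 to compound 3.

The shared core carries a nitrofuran hydrazone, and the compounds differ only in the substituent on the benzoyl ring. Compound 1 `CC(C)(C)c1ccc(C(=O)N/N=C/c2ccc([N+](=O)[O-])o2)cc1` carries a tert-butyl group. In an ADME assay on U2OS cells (Homo sapiens) for cytotoxicity (a higher number here means that more compound is tolerated, a lower number that less compound is tolerated), compound 1 gives only a limit of the assay, > 200000 nM, and no number. Compound 2 `O=C(N/N=C/c1ccc([N+](=O)[O-])o1)c1ccc(-c2ccccc2)cc1` carries a phenyl group instead. In this assay, among the measured compounds shown here, compound 2 gives 109000 nM, which is the only number so far. For the measured compounds named here, the one measured step, an at least 1.8-fold lower number from compound 1 to compound 2 (0.26 log units; that floor lies within the scatter), rests on the limit of > 200000 nM in this assay, at which 1 of the 2 values shown sits, and so is bounded only on one side.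

Compound 3 `N#Cc1ccc(C(=O)N/N=C/c2ccc([N+](=O)[O-])o2)cc1` is not yet measured. It differs from compound 2 by cyano in place of phenyl on an aromatic carbon. Going by the values given here, no measured step involves cyano, and the only step at hand, the one from compound 1 to compound 2, runs the other way, from a small alkyl to phenyl, and its floor lies within the scatter. Taking the phenyl away again is therefore expected to give at most a modest shift toward a higher number in this assay, possibly none beyond the scatter. For compound 3 the estimated step is a 1.4-fold higher number from compound 2 to compound 3 (0.14 log units; within the scatter). Compound 3 is thus expected to give about 150000 nM in this assay, within a range of 70000 nM to 320000 nM, with a fair chance that only a limit is reported.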

Compound 3, half-maximal cytotoxic concentration: 21400 nM
Estimate against measurement, compound 3: 7.0-fold (0.85 log units) above; measured number outside the range, below it.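

In this assay, among the compounds shown here, cyano in place of phenyl on an aromatic carbon, para to a large group, gives a 5.1-fold lower number from compound 2 to compound 3 (0.71 log units; beyond the scatter); this is the first step that joins two actual numbers and lies beyond the scatter. Cyano in place of tert-butyl at the same position gives an at least 9.3-fold lower number from compound 1 to compound 3 (0.97 log units; beyond the scatter), so compound 3 has the lowest number of the three, and the substituent at this position clearly moves the tolerated concentration, with fewer heavy atoms in the entering group than in phenyl not bringing a higher number. Compound 1 gives only a limit of the assay, so the step from it remains a floor, open on one side: the limit of > 200000 nM in this assay, at which 1 of the 3 values shown sits.

The three substituents leave open whether the lower number belongs to cyano in particular or would also appear with other small groups at this position, such as an amine, a carboxylic acid or a methoxy group. They also leave open how much of the tolerated concentration is set by the shared core and how much by this substituent, as every comparison here changes the one position only.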